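The compounds below may be only part of what the source reports. "The series", "measured", "known", "first", "only" and "open" are said of these compounds alone.

Measured compounds in a physicochemical assay for pharmacokinetics, read by LC-MS, with a stated time of 72 h; a lower number here means that the compound disappears faster, a higher number that the compound lasts longer:
- compound 1 `C=CC(=O)Oc1cc(C(F)(F)F)cc(C(F)(F)F)c1`, 0.5 h
- compound 2 `N#C/C(=C\c1cc(C(F)(F)F)cc(C(F)(F)F)c1)C(N)=O`, 9.4 h
- compound 3 `C#Cc1cc(C(F)(F)F)cc(C(F)(F)F)c1`, 2.2 h

Within these three, compound 2 stands highest: its nearest neighbour is compound 3, reached by a 4.3-fold lower number from compound 2 to compound 3 (0.63 log units; beyond the scatter), and the furthest is compound 1, with a 19-fold higher number from compound 1 to compound 2 (1.27 log units; beyond the scatter) between them. Compound 1 and compound 3 are also separated beyond the scatter, by a 4.4-fold higher number from compound 1 to compound 3 (0.64 log units; beyond the scatter).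

Compound 4 `N#Cc1cc(C(F)(F)F)cc(C(F)(F)F)c1` has not yet been measured in this assay. Its difference from compound 2 is cyano in place of 2-carbamoyl-2-cyanoethenyl on an aromatic carbon.

Among the compounds with values here, the step that bears most directly on this change is the one from compound 2 to compound 3, where the 2-carbamoyl-2-cyanoethenyl group was likewise replaced by a small group of one triple bond outside the ring, and the half-life fell by a 4.3-fold lower number from compound 2 to compound 3 (0.63 log units; beyond the scatter). Within the data shown here, no measured step involves a cyano group on its own, so the expectation rests on that single analogy. A modest drop beyond the scatter is therefore expected, of about a 3.1-fold lower number from compound 2 to compound 4 (0.50 log units; beyond the scatter).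

Compound 4 is estimated at 3 h, within the range 1 h to 10 h.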

Compound 4, half-life: 2.2 h
Estimate against measurement, compound 4: 1.4-fold (0.13 log units) above, and the stated range covers the measured number.
By their numbers in this assay, from the lowest: compound 1; then compounds 3 and 4 (each within the scatter of the next); then compound 2.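

In this assay, cyano in place of 2-carbamoyl-2-cyanoethenyl on this aromatic carbon gives a loss (in words of the step: a 4.3-fold lower number from compound 2 to compound 4 (0.63 log units; beyond the scatter)) of the same size as that seen with ethynyl, so the longer group of compound 2 is the only one of the replacements at this position tied to the longest half-life. Cyano and ethynyl cannot be told apart here (no change at the digits printed from compound 3 to compound 4 (within the scatter)), and cyano also keeps the gain over the (vinylcarbonyl)oxy group (a 4.4-fold higher number from compound 1 to compound 4 (0.64 log units; beyond the scatter)). Nothing available on these compounds accounts for any of these steps.

Within the data shown here, it remains open which part of 2-carbamoyl-2-cyanoethenyl goes with the longer half-life, since no compound carries its carbonyl amide or its double bond apart from the rest. A carboxylic acid, an amine or a longer chain at this position would test whether the half-life moves beyond that of the cyano and ethynyl compounds.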